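From 4-fluorophenyl to 3,4-dichlorophenyl at the series limit

The source may report more compounds than this note shows. Statements on the series, on what has been measured and on what is new or still open speak of the compounds shown alone.

Measured so far in a functional assay on HepG2 cells (Homo sapiens) for cytotoxicity, with a stated time of 72 h (a lower number here means that less compound is needed, a higher number that more compound is needed for the effect), each value a limit and not a number:
- compound 1 `C=C[C@@](C)(/C=C/c1ccc(Nc2ccc(OC)cc2)cc1)CCC=C(C)C` gives > 52000 nM as a limit
- compound 2 `C=C[C@@](C)(/C=C/c1ccc(Nc2ccc(F)c(F)c2)cc1)CCC=C(C)C` gives > 52000 nM as a limit
- compound 3 `C=C[C@@](C)(/C=C/c1ccc(-c2ccc(F)cc2)cc1)CCC=C(C)C` gives > 52000 nM as a limit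

Compound 3 stands with the limit of > 52000 nM in this assay, at which 3 of the 3 values shown sit, and so cannot be ranked against the other two. Compound 4 `C=C[C@@](C)(/C=C/c1ccc(-c2ccc(Cl)c(Cl)c2)cc1)CCC=C(C)C` carries 3,4-dichlorophenyl in place of 4-fluorophenyl on an aromatic carbon, para to a large group: 3,4-dichlorophenyl in place of 4-fluorophenyl on an aromatic carbon.

Two measured steps change the group at this place: a step that the two limits leave unreadable from compound 1 to compound 3 and a step that the two limits leave unreadable from compound 2 to compound 3. The third is a step that the two limits leave unreadable from compound 1 to compound 2 and changes the aryl group on the nitrogen. None of these has a readable size, so none gives a direction for the new change. In this assay no step beyond the scatter is expected, and compound 4 is expected to report the same limit. The expected step is a step that the limit leaves unreadable from compound 3 to compound 4 and it remains an estimate only. The estimate for compound 4 is 55000 nM with an expected range from 25000 nM to 100000 nM and rests on limits alone.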

Compound 4, half-maximal effective concentration: > 52000 nM
Compound 4: a limit, no number (the forecaster's own chance of this, stated with the estimate: 75%); the middle value is on the limit's open side.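

In this assay compound 4 gives > 52000 nM, a limit and not a number. Among the compounds shown here, no step from compound 1, compound 2 or compound 3 to compound 4 can be read. The compounds shown leave open how the four rank against one another and what numerical value any of them would give.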